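The source may report more compounds than this note shows. Statements on the series, on what has been measured and on what is new or still open speak of the compounds shown alone.

Within the data shown here, in a functional assay on HepG2 cells (Homo sapiens) for inhibition, read by MTT assay, with a stated time of 72 h (a lower number here means a stronger inhibitor, a higher number a weaker inhibitor), compound 1 `Nc1nc2cc(-c3nn(CCCCCCCCCC(=O)NO)c4ncnc(N)c34)ccc2o1` gives 28600 nM, the higher of the two numbers so far, while compound 2 `Nc1ncnc2c1c(-c1cnc3[nH]ccc3c1)nn2CCCCCCCCCC(=O)NO` gives 11700 nM. Compound 3 `Nc1nc2cc(-c3nn(CCCCC(=O)NO)c4ncnc(N)c34)ccc2o1` keeps the core of compound 1 but shortens its chain, with hydroxycarbamoyl in place of 5-(hydroxycarbamoyl)pentyl on a saturated chain carbon, four bonds along the chain from an aromatic nitrogen. Among the measured compounds shown here, the only measured step, a 2.4-fold lower number from compound 1 to compound 2 (0.39 log units; beyond the scatter), is modest and changes the aromatic group, not the chain, so the effect of chain length remains untested. The expected change is therefore small and within the scatter, an estimated 1.4-fold lower number from compound 1 to compound 3 (0.16 log units; within the scatter). Compound 3 is expected at 20000 nM, with an estimated range of 5000 nM to 60000 nM.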

Compound 3, half-maximal inhibitory concentration: 2100 nM
Compound 3: the middle estimate sits 9.5-fold (0.98 log units) above what was measured, and the stated range ends above it.
By their numbers in this assay, from the lowest: compound 3; then compound 2; then compound 1.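

In this assay the chain carrying the hydroxycarbamoyl end matters: shortening it gives a 14-fold lower number from compound 1 to compound 3 (1.13 log units; beyond the scatter), a large step, whereas the change of aromatic group gave only a 2.4-fold lower number from compound 1 to compound 2 (0.39 log units; beyond the scatter). The end group and the shared core stay the same, so this step comes from the chain alone. Nothing measured here explains why the shorter chain gives the lower number.

From the compounds shown here alone, whether a still shorter or intermediate chain would go lower remains open, as does the same shortening on compound 2. A carboxylic acid or an amine at the chain end also remains untested among these compounds.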